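The source may report more compounds than this note shows. Statements on the series, on what has been measured and on what is new or still open speak of the compounds shown alone.

Compound 1 `Cc1cc(I)cn2c(CSCCc3ccccc3)cnc12` is the anchor of this account. In an ADME assay on HEL cells (Homo sapiens) for cytotoxicity, with a stated time of 3 days (on this read-out higher numbers stand for lower toxicity in this test and lower numbers for higher toxicity in this test), compound 1 gives >= 0.8 ug/mL, which is a limit of the assay rather than a measured number, so its true standing among the values shown is not fixed; it sits at the limit of >= 0.8 ug/mL in this assay, at which 1 of the 3 values shown sits. Two other compounds carry numbers there: compound 2 `Cc1cc(-c2ccccc2)c2ncc(CSCCc3ccccc3)n2c1` gives 20 ug/mL in this assay, and compound 3 `Cc1cc(-c2cccc([N+](=O)[O-])c2)c2ncc(CSCCc3ccccc3)n2c1` gives 100 ug/mL. For the measured compounds named here, the only change among them with a known size is a 5.0-fold higher number from compound 2 to compound 3 (0.70 log units; beyond the scatter). Compound 4 `Cc1cc(Br)cn2c(CSCCc3ccccc3)cnc12` differs from compound 1 by bromo in place of iodo on an aromatic carbon. Going by the values given here, no measured step involves the exchange of one halogen for another, so the step from compound 2 to compound 3 gives only a general sense of how far a single substituent change has moved this read-out here. With compound 1 resting on a limit, the expectation is that compound 4 stays within the scatter of compound 1, a step that the limit leaves unreadable from compound 1 to compound 4. Compound 4 is therefore estimated at 2 ug/mL, with a range from 0.8 ug/mL to 10 ug/mL, and a fair chance that the assay again reports only a limit.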

Compound 4, minimum cytotoxic concentration: >= 2 ug/mL
Compound 4: only a limit was reported; the forecaster's own chance of this, stated with the estimate: 50%; the middle value lies on the limit itself.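

Compound 1 and compound 4 each carry only a limit in this assay, not a number, and the step between them cannot be read. The compounds shown leave open where the true values of compound 1 and compound 4 lie, and how far bromo in place of iodo moves this read-out.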